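Swapping Phenyl for Thiophen-3-yl on a Shared Core

The source may report more compounds than this note shows. Statements on the series, on what has been measured and on what is new or still open speak of the compounds shown alone.

Of the compounds shown here, three on the shared core have been tested in a functional assay on HL-60 cells (Homo sapiens) for antiproliferative activity, read by XTT assay, with a stated time of 72 h; on this read-out higher numbers stand for weaker inhibition and lower numbers for stronger inhibition. Compound 1 `COc1nc(N)nc2c1c(-c1ccccc1)cn2[C@@H]1O[C@H](CO)[C@@H](O)[C@H]1O` gives only a limit in this assay, > 20000 nM. Compound 2 `COc1ncnc2c1c(-c1ccccc1)cn2[C@@H]1O[C@H](CO)[C@@H](O)[C@H]1O` likewise returns a limit in this assay, > 20000 nM. Compound 3 `CNc1ncnc2c1c(-c1ccccc1)cn2[C@@H]1O[C@H](CO)[C@@H](O)[C@H]1O` also stops at a limit in this assay, > 20000 nM. Compound 2 thus stands at the same limit as the other two, so that the limit of > 20000 nM in this assay, at which 3 of the 3 values shown sit, is all the comparison offers. The step from compound 1 to compound 2, a step that the two limits leave unreadable from compound 1 to compound 2, and the step from compound 2 to compound 3, a step that the two limits leave unreadable from compound 2 to compound 3, are both hidden behind this limit.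

Compound 4 `COc1ncnc2c1c(-c1ccsc1)cn2[C@@H]1O[C@H](CO)[C@@H](O)[C@H]1O` differs from compound 2 in one place: thiophen-3-yl in place of phenyl on an aromatic carbon. Among the measured compounds shown here, no measured step speaks to this exchange; the two that exist are unreadable, and all three values sit at the same limit. There is thus no basis for expecting a readable shift in this assay from compound 2 to compound 4, and the estimated step that the limit leaves unreadable from compound 2 to compound 4 is little more than a placeholder. Compound 4 is expected to give around 30000 nM in this assay, between 8000 nM and 120000 nM, and most likely to be reported once more as a limit.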

Compound 4, half-maximal inhibitory concentration: 130 nM
For compound 4 the middle estimate is 230-fold (2.36 log units) above the measured one; measured number outside the range, below it.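

All three earlier compounds carry phenyl on this aromatic carbon, two ring bonds from the ring nitrogen, and they differ from one another only elsewhere on the shared core, so none of them tested what the group at this place can do. In this assay, thiophen-3-yl in place of phenyl gives an at least 150-fold lower number from compound 2 to compound 4 (2.18 log units; beyond the scatter), which shows that a single exchange at this place can turn a compound with no readable value into one with a readable value. The size of that step is only a lower bound, and compound 4 holds the one readable number in the set, with the rest of the series still at the limit: the limit of > 20000 nM in this assay, at which 3 of the 4 values shown sit.

The compounds shown leave open whether this gain belongs to thiophen-3-yl alone or would also appear with another group on the same carbon, such as furan-3-yl, pyridin-3-yl or thiophen-2-yl. They also leave open whether thiophen-3-yl would have the same effect with the amino group of compound 1 present, or with the methylamino group of compound 3 in place of methoxy.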